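Swapping halogens at the para position: compound 3 to compound 4

The source may hold more compounds than are shown below. What is called first, only, known or untested is meant among the compounds shown, and "the series" means these compounds.

Of the compounds shown here, three share one core and have been tested in a functional assay on the whole organism for inhibition, with Rattus norvegicus as the target, read by paw edema, with a stated time of 4 h, at a dose of 50 mg/kg; on this read-out lower numbers stand for less inhibition and higher numbers for more inhibition at the one dose given (going by the name of the read-out). Compound 1, `Cc1cc2nn(-c3ccccc3)c(C)c2c(=O)o1`, gives 43.1%. Compound 2, `Cc1ccc(-n2nc3cc(C)oc(=O)c3c2C)cc1`, gives 41.7%. Compound 3, `Cc1cc2nn(-c3ccc(Cl)cc3)c(C)c2c(=O)o1`, gives 38.2%. Compound 3 has the lowest of the three numbers, but its gaps to the others are small: the step of a number 4.9 percentage points lower from compound 1 to compound 3 (within the scatter) and the step of a number 3.5 percentage points lower from compound 2 to compound 3 (within the scatter) are both within the scatter, as is a number 1.4 percentage points lower from compound 1 to compound 2 (within the scatter). In other words, none of the three has yet been told apart from the others.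

Compound 4, `Cc1cc2nn(-c3ccc(Br)cc3)c(C)c2c(=O)o1`, remains to be measured. It differs from compound 3 as follows: bromo in place of chloro on an aromatic carbon. Going by the values given here, the steps that bear on this change are the two that put a chloro onto the same carbon, from compound 1 and from compound 2, and both stayed within the scatter. Exchanging one halogen for another at the same place is therefore expected to move the number little, with an expected step of a number 1.2 percentage points lower from compound 3 to compound 4 (within the scatter) in this assay. Compound 4 is estimated to give 37%, within a range from 27% to 47%.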

Compound 4, a percentage reported as inhibition, in the whole organism at one dose (the size of the read-out at that dose, not a potency): 38.2%
For compound 4 the middle estimate is 1.2 percentage points below the measured one; the range from low to high includes it.
By their numbers in this assay, from the lowest: compounds 3, 4, 2 and 1 (each within the scatter of the next).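

In this assay, going by these compounds alone, bromo in place of chloro at this carbon gives (no change at the digits printed from compound 3 to compound 4 (within the scatter)), a direct comparison of two halogens that the earlier compounds could not offer. Bromo also stands against hydrogen and methyl much as chloro did, with (a number 4.9 percentage points lower from compound 1 to compound 4 (within the scatter)) and (a number 3.5 percentage points lower from compound 2 to compound 4 (within the scatter)). Hydrogen, methyl, chloro and bromo on this aromatic carbon, para to a large group, therefore cannot be told apart at this one dose.

As far as these compounds go, whether a group of a different kind at this place, such as an amine or a carboxylic acid, would give a number beyond the scatter remains open. Nothing at hand explains why these four compounds give such close numbers.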